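Benzyl ether variation: from compound 3 to compound 4

This account rests on a few compounds, and the source may have more. Where it says the series, first, only, none or still open, it means among the compounds named here.

Measured so far in a functional assay on MGC-803 cells (Homo sapiens) for inhibition, read by MTT assay, with a stated time of 48 h; a lower number here means a stronger inhibitor, a higher number a weaker inhibitor:
compound 1 `Cc1ccc(NC(=O)NC(=O)c2ccc(OCc3cccc(C(F)(F)F)c3)cc2)cc1-c1nc2ccccc2[nH]1` gives 13100 nM.
compound 2 `Cc1ccc(NC(=O)NC(=O)c2ccc(OCc3ccccc3F)cc2)cc1-c1nc2ccccc2[nH]1` gives 2520 nM.
compound 3 `Cc1ccc(NC(=O)NC(=O)c2ccc(OCc3cccc(Cl)c3Cl)cc2)cc1-c1nc2ccccc2[nH]1` gives only a limit of the assay, > 100000 nM.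

Compound 3 stands at the weak end of the three. Its value is a limit, not a number, (the limit of > 100000 nM in this assay, at which 1 of the 3 values shown sits), so only the direction of its distance from the other two is fixed. The two steps leading to it, an at least 7.6-fold higher number from compound 1 to compound 3 (0.88 log units; beyond the scatter) and an at least 39-fold higher number from compound 2 to compound 3 (1.59 log units; beyond the scatter), both run toward weaker inhibition, and among the two groups that do give numbers the spread is a 5.2-fold lower number from compound 1 to compound 2 (0.72 log units; beyond the scatter).

Compound 4 `Cc1ccc(COc2ccc(C(=O)NC(=O)Nc3ccc(C)c(-c4nc5ccccc5[nH]4)c3)cc2)cc1` differs from compound 3 by 4-methylphenyl in place of 2,3-dichlorophenyl on a saturated chain carbon bound to an oxygen on an aromatic ring. For the measured compounds named here, no measured step carries a 4-methylphenyl group, so the expectation rests on the two steps into compound 3 read in reverse: removing the 2,3-dichlorophenyl group is expected to bring the number back into the range spanned by compound 1 and compound 2, without a firm basis for placing it nearer either. The step is estimated as an at least 12-fold lower number from compound 3 to compound 4 (1.09 log units; beyond the scatter).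

Compound 4 is therefore expected to give about 8000 nM in this assay, with a range from 2000 nM to 40000 nM.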

Compound 4, half-maximal inhibitory concentration: 4250 nM
Compound 4: middle estimate off by 1.9-fold (0.27 log units), on the high side; the range from low to high includes it.
By their numbers in this assay, from the lowest: compounds 2 and 4 (each within the scatter of the next); then compound 1. At a limit, above all of these: compound 3.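

In this assay, the benzyl ether position gives a measurable value again with 4-methylphenyl in place of 2,3-dichlorophenyl, an at least 23-fold lower number from compound 3 to compound 4 (1.37 log units; beyond the scatter), and this size is only a lower bound. Compound 3 remains at a limit of the assay rather than a number: the limit of > 100000 nM in this assay, at which 1 of the 4 values shown sits. All the earlier groups at this place carry halogen, and 4-methylphenyl now shows that a ring with no halogen also gives a value in the same range, with a 1.7-fold higher number from compound 2 to compound 4 (0.23 log units; within the scatter) and a 3.1-fold lower number from compound 1 to compound 4 (0.49 log units; beyond the scatter), so the first of these steps leaves 4-methylphenyl and 2-fluorophenyl indistinguishable while the second separates 4-methylphenyl from 3-(trifluoromethyl)phenyl.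

The compounds shown leave open whether the loss seen with 2,3-dichlorophenyl needs both chlorines, as a 2-chlorophenyl or a 3-chlorophenyl group would show. Also open, as far as these compounds go, is how this place responds to an unsubstituted phenyl ring, or to a ring bearing a methoxy group, a nitrile or an amine, and whether the 4-methylphenyl and 2-fluorophenyl results would carry over to those groups.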